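The source may report more compounds than this note shows. Statements on the series, on what has been measured and on what is new or still open speak of the compounds shown alone.

Measured compounds:
- compound 1, `Cc1cc(C)c(-n2c(Cl)cn3c(CN(CCC(F)(F)F)CC4CC4)c(C(F)(F)F)nc23)c(C)c1`; in an assay on cells for displacement of a labelled ligand from corticotropin-releasing factor receptor 1 (Homo sapiens), with a stated time of 100 min (on this read-out lower numbers stand for stronger inhibition and higher numbers for weaker inhibition), compound 1 gives 16 nM
- compound 2, `CCCCN(CC)Cc1c(C(F)(F)F)nc2n(-c3c(C)cc(C)cc3C)c(Cl)cn12`; in this assay compound 2 gives 78 nM

Among the measured compounds shown here, compound 2 holds the higher of the two numbers; the one step recorded, a 4.9-fold higher number from compound 1 to compound 2 (0.69 log units; beyond the scatter), shows that exchanging the substituents on the amine nitrogen moves the read-out by a modest amount beyond the scatter.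

Compound 3, `CCCCN(C)Cc1c(C(F)(F)F)nc2n(-c3c(C)cc(C)cc3C)c(Cl)cn12`, is not yet measured. It differs from compound 2 by hydrogen in place of methyl on a saturated chain carbon bound to an amine nitrogen, that is, ethyl to methyl on the amine. For the measured compounds named here, no measured step covers this exact change; the step from compound 1 to compound 2 is the only one on the amine substituents and it involved much larger groups, so it gives only a loose sense of scale. A change of one carbon on the amine is expected to stay within the scatter or at most shift slightly towards a higher number.

For compound 3 in this assay the expected value is 95 nM, with a range of 35 nM to 250 nM, which amounts to an expected step of a 1.2-fold higher number from compound 2 to compound 3 (0.09 log units; within the scatter).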

Compound 3, inhibition constant: 310 nM
Estimate against measurement, compound 3: 3.3-fold (0.51 log units) below; measured number outside the range, above it.
By their numbers in this assay, from the lowest: compound 1; then compound 2; then compound 3.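

In this assay the change from ethyl to methyl on the amine nitrogen gives a 4.0-fold higher number from compound 2 to compound 3 (0.60 log units; beyond the scatter) so that even this single-carbon difference on a saturated chain carbon bound to an amine nitrogen lies beyond the scatter. Among these three compounds the number rises in the order of (cyclopropylmethyl)(3,3,3-trifluoropropyl)amino, butyl(ethyl)amino and butyl(methyl)amino, and the two ends of that order are separated by a 19-fold higher number from compound 1 to compound 3 (1.29 log units; beyond the scatter) with no compound going against it. No measurement shown here accounts for the effect of this change.

Still open, as far as these compounds go, is whether a propyl chain in place of ethyl on the butyl-bearing amine would lower the number further. The separate contributions of cyclopropylmethyl and 3,3,3-trifluoropropyl also remain unresolved, as these two groups appear only together, in compound 1.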